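The source may report more compounds than this note shows. Statements on the series, on what has been measured and on what is new or still open speak of the compounds shown alone.

Compound 1, `O=C(O)COC(=O)N(C1CC1)[C@H]1c2ccccc2N(C(=O)c2cccc(F)c2)[C@H]2CC[C@H]21`, gives 13 nM in a functional assay for antagonist activity at prostaglandin D2 receptor 2 (Homo sapiens), read by flow cytometry, with stated times of 10 min and 4 min; a lower number here means a stronger inhibitor, a higher number a weaker inhibitor.
Compound 2, `O=C(O)CCC(=O)N(C1CC1)[C@H]1c2ccccc2N(C(=O)c2ccc(F)cc2)[C@H]2CC[C@H]21`, gives 8.9 nM in this assay.

On these two numbers compound 2 sits at the low end, but compound 1 lies within the usual scatter of it, so the two cannot be told apart. Compound 3, `O=C(O)COC(=O)N(C1CC1)[C@H]1c2ccccc2N(C(=O)c2ccc(F)cc2)[C@H]2CC[C@H]21`, has not been measured in this assay. It differs from compound 2 in one place: carboxymethoxy in place of 2-carboxyethyl on a carbonyl carbon. Among the compounds with values here, no measured pair shows this exchange on an otherwise identical core; compound 1 carries the carboxymethoxycarbonyl group as well, but its fluorine sits elsewhere, so its number is only a loose guide. Since compound 1 gives 13 nM and compound 2 gives 8.9 nM, the step from compound 2 to compound 3 in this assay is expected to be small, a 1.3-fold higher number from compound 2 to compound 3 (0.13 log units; within the scatter), in no clear direction beyond the scatter. Compound 3 is therefore estimated at 12 nM, in the range 5 nM to 30 nM.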

Compound 3, half-maximal inhibitory concentration: 3.6 nM
Beside the measured number, compound 3's estimate is 3.3-fold (0.52 log units) above it, outside the stated range (below it).
By their numbers in this assay, from the lowest: compound 3; then compounds 2 and 1 (each within the scatter of the next).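

In this assay, within the data shown here, carboxymethoxy in place of 2-carboxyethyl on a carbonyl carbon gives a 2.5-fold lower number from compound 2 to compound 3 (0.39 log units; beyond the scatter), so this exchange, which no earlier pair isolated, has a modest but real effect on the shared core. The place of the fluorine matters too: with the carboxymethoxycarbonyl group held fixed, 4-fluorophenyl in place of 3-fluorophenyl on a carbonyl carbon gives a 3.6-fold lower number from compound 1 to compound 3 (0.56 log units; beyond the scatter), also modest and beyond the scatter. Nothing at hand accounts for either step.

Going by these compounds, whether the step from 2-carboxyethyl to carboxymethoxy would carry over to compounds bearing 3-fluorophenyl stays open. So does how a longer chain ending in a carboxylic acid, an amine in place of the acid, or a chlorine in place of the fluorine would read here.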